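The compounds below may be only part of what the source reports. "The series", "measured", "known", "first", "only" and "open" are said of these compounds alone.

Working notes on the benzoxazole-free description: the series shares the core of compound 1 `O=S(=O)(Nc1ccc2oc(-c3ccc(NS(=O)(=O)c4cccc5nonc45)cc3)nc2c1)c1ccc(Cl)s1`, carrying two sulfonamide arms, and in an assay on cells for inhibition of HSP60/HSP10 (Homo sapiens), with a stated time of 60 min (a higher number here means a weaker inhibitor, a lower number a stronger inhibitor), compound 1 gives 13000 nM. Compound 2 `O=S(=O)(Nc1ccc2oc(-c3ccccc3)nc2c1)c1ccccc1Cl` keeps one sulfonamide arm only. In this assay compound 2 is recorded only as a limit, > 100000 nM, so no number stands for it. Of the two values shown, one sits at that limit (the limit of > 100000 nM in this assay, at which 1 of the 2 values shown sits); compound 2 is thus the weaker of the two where a comparison can be made at all.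

Compound 3 `Cc1cccc(S(=O)(=O)Nc2ccc3oc(-c4ccccc4)nc3c2)c1` differs from compound 2 by 3-methylphenyl in place of 2-chlorophenyl on a sulfonyl sulfur. Among the compounds with values here, no measured step of this kind is available in the data. With compound 2 at the limit, the step from compound 2 to compound 3 is expected to be small, a number no higher from compound 2 to compound 3 (the limit leaves the size open), and no change beyond the scatter is expected in this assay. For compound 3 the estimate in this assay is 100000 nM, with a range from 30000 nM to 300000 nM, and a second limit is the more likely outcome.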

Compound 3, half-maximal inhibitory concentration: > 100000 nM
Compound 3: only a limit was reported; the forecaster's own chance of this, stated with the estimate: 70%; the middle value sits exactly at the limit.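

Compound 2 and compound 3 both stand only as limits in this assay, so no step can be read between them: the limit of > 100000 nM in this assay, at which 2 of the 3 values shown sit.

The compounds shown leave open whether 3-methylphenyl and 2-chlorophenyl on a sulfonyl sulfur differ at all in this series.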